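A few compounds are considered here, and "the series" means these few. Any claim that something is new, unique, unknown or untested is made for them only; others in the source may bear on it.

Measured compounds:
compound 1 `CC(=O)c1cc2ccc(OCCCn3cc(CNC(=O)CCCCC4CCSS4)nn3)cc2oc1=O` — 34.6%
compound 2 `CCOC(=O)c1cc2ccc(OCCCn3cc(CNC(=O)CCCCC4CCSS4)nn3)cc2oc1=O` — 28%
compound 3 `O=C(CCCCC1CCSS1)NCc1cn(CCCOc2ccc3cc(-c4ccccc4)c(=O)oc3c2)nn1` — 33.9%

In a functional assay on PC-12 cells (Rattus norvegicus) for cytotoxicity, read by MTT assay, with stated times of 3 h and 2 h, tested at 0.1 uM (on this read-out lower numbers stand for a weaker effect and higher numbers for a stronger effect at the one concentration tested), compound 3 gives 33.9%, the second highest of the three numbers; all three values sit within the usual scatter of one another, so no ordering among them can be read. The changes at the same aromatic carbon of the shared core, a number 0.7 percentage points lower from compound 1 to compound 3 (within the scatter) and a number 5.9 percentage points higher from compound 2 to compound 3 (within the scatter), were both within the scatter, as was the change at the carbonyl carbon, a number 6.6 percentage points lower from compound 1 to compound 2 (within the scatter). Compound 4 `COc1ccc(-c2cc3ccc(OCCCn4cc(CNC(=O)CCCCC5CCSS5)nn4)cc3oc2=O)cc1` differs from compound 3 by methoxy in place of hydrogen on an aromatic carbon. Going by the values given here, no measured step touches the phenyl group itself, so there is no direct precedent; the only guide is that every substitution tried so far on this core left this assay unchanged within the scatter. The expectation is therefore a step of about a number 0.1 percentage points higher from compound 3 to compound 4 (within the scatter), not beyond the scatter. Compound 4 is estimated at 34%, with a range from 24% to 44%.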

Compound 4, a percentage reported as activity, at one concentration (the size of the read-out at that concentration, not a potency): 42%
Estimate against measurement, compound 4: 8 percentage points below; low and high end bracket the measured number.
By their numbers in this assay, from the lowest: compounds 2, 3, 1 and 4 (each within the scatter of the next, the first and the last beyond it).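

In this assay, the phenyl group itself is substituted for the first time among the compounds shown, and phenyl to 4-methoxyphenyl gives a number 8.1 percentage points higher from compound 3 to compound 4 (within the scatter) on this read-out, so methoxy at this place on the ring yields no step that can be told from the scatter. Set against the acetyl group, the 4-methoxyphenyl group gives a number 7.4 percentage points higher from compound 1 to compound 4 (within the scatter) and is likewise not separable, whereas a number 14 percentage points higher from compound 2 to compound 4 (beyond the scatter) is the only step in the series beyond the scatter, and it is modest in size. The data offer no independent measurement that could account for this single readable step.

As far as these compounds go, what an amine, a carboxylic acid or a longer alkoxy chain in place of the methoxy would give in this assay stays open. From the compounds shown here alone, with a single tested concentration, how these compounds compare at other concentrations also stays open.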